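Replacing a chain hydroxyl by methylamino in a pyridylbenzyl series

The source may hold more compounds than are shown below. What is called first, only, known or untested is meant among the compounds shown, and "the series" means these compounds.

Compound 1, `CC(C)c1n[nH]c2c(NCc3ccc(-c4ccccn4)cc3)nc(SCCN)nc12`, gives 22 nM in a functional assay on HT cells (Homo sapiens) for antiproliferative activity, read by fluorescence, with a stated time of 72 h; on this read-out lower numbers stand for stronger inhibition of growth and higher numbers for weaker inhibition of growth.
Compound 2, `CC(C)c1n[nH]c2c(NCc3ccc(-c4ccccn4)cc3)nc(SCCCO)nc12`, gives 109 nM in this assay.

Compound 2 has the highest number of the two measured in this assay; its nearest neighbour is compound 1, which lies a 5.0-fold higher number from compound 1 to compound 2 (0.70 log units; beyond the scatter) away in the other direction. Compound 3, `CNCCSc1nc(NCc2ccc(-c3ccccn3)cc2)c2[nH]nc(C(C)C)c2n1`, differs from compound 2 by methylamino in place of hydroxymethyl on a saturated chain carbon, two bonds along the chain from a sulfur. Within the data shown here, the only step that bears on it is a 5.0-fold higher number from compound 1 to compound 2 (0.70 log units; beyond the scatter), which runs in the opposite direction and exchanges amino for hydroxymethyl at the same place. Compound 3 largely undoes that exchange, keeping a basic chain end as in compound 1 but with a methyl on the nitrogen. A step of roughly that size back toward lower numbers is therefore expected, a 3.6-fold lower number from compound 2 to compound 3 (0.56 log units; beyond the scatter), with some uncertainty from the added methyl. Compound 3 is estimated at 30 nM, with a range from 12 nM to 80 nM.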

Compound 3, concentration for 50% growth inhibition: 56 nM
Estimate against measurement, compound 3: 1.9-fold (0.27 log units) below, within the range that was stated.
By their numbers in this assay, from the lowest: compound 1; then compounds 3 and 2 (each within the scatter of the next).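

In this assay, methylamino in place of hydroxymethyl at this place on the chain gives a 1.9-fold lower number from compound 2 to compound 3 (0.29 log units; within the scatter), so compound 3 and compound 2 cannot be told apart and this exchange alone does not bring the chain to the level of compound 1. Methyl in place of hydrogen on the amine nitrogen gives a 2.5-fold higher number from compound 1 to compound 3 (0.41 log units; beyond the scatter), a modest step, which shows that this position responds to a single methyl on the nitrogen and sets the primary amine of compound 1 apart from compound 3. No measurement here accounts for this difference.

From the compounds shown here alone, whether a dimethylamino group at the chain end would stand with compound 1 or with compound 3 remains open. So does the effect of a longer chain carrying a primary amine.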